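This account rests on a few compounds, and the source may have more. Where it says the series, first, only, none or still open, it means among the compounds named here.

Within the data shown here, in a functional assay on HepG2 cells (Homo sapiens) for inhibition, read by MTT assay (on this read-out higher numbers stand for weaker inhibition and lower numbers for stronger inhibition), compound 1 (`O=S(=O)(c1ccc(-c2cnc(C3CC3)o2)cc1)N1CCc2ccccc21`) gives 58 nM as the lowest of three numbers so far. Compound 2 (`CC1Cc2ccccc2N1S(=O)(=O)c1ccc(-c2cnc(C3CC3)o2)cc1`) gives 16800 nM and compound 3 (`O=S(=O)(c1ccc(-c2cnc(C3CC3)o2)cc1F)N1CCc2ccccc21`) gives 18700 nM in the same read-out. Compound 4 (`C=Cc1ncc(-c2ccc(S(=O)(=O)N3CCc4ccccc43)cc2)o1`) has vinyl in place of cyclopropyl on an aromatic carbon. Neither measured step touches that place: a 290-fold higher number from compound 1 to compound 2 (2.46 log units; beyond the scatter) follows methyl in place of hydrogen on a saturated ring carbon, and a 320-fold higher number from compound 1 to compound 3 (2.51 log units; beyond the scatter) follows fluoro in place of hydrogen on an aromatic carbon. Both steps are large, but no measurement covers this group, so a smaller step toward a higher number is expected in this assay here. The expected step is a 6.9-fold higher number from compound 1 to compound 4 (0.84 log units; beyond the scatter) on this reasoning. For compound 4 the estimate is 400 nM with an expected range of 50 nM to 5000 nM in this assay.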

Compound 4, half-maximal inhibitory concentration: 25800 nM
Compound 4: the middle estimate sits 65-fold (1.81 log units) below what was measured, and the stated range ends below it.
By their numbers in this assay, from the lowest: compound 1; then compounds 2, 3 and 4 (each within the scatter of the next).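

Cyclopropyl on the aromatic carbon between the ring nitrogen and ring oxygen is not freely exchangeable: in this assay, vinyl in its place gives a 440-fold higher number from compound 1 to compound 4 (2.65 log units; beyond the scatter). Among these compounds, this is the first measured change at this position, and its step is large, as are those at the two other places changed from compound 1. Nothing available explains the step. Going by these compounds, whether ethyl, isopropyl or cyclobutyl at this position would keep the number close to that of compound 1 remains open.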